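A New Aromatic Group at an Untested Place

The source may hold more compounds than are shown below. What is called first, only, known or untested is meant among the compounds shown, and "the series" means these compounds.

In a functional assay on the whole organism (strain Kunming) with Mus musculus as the target, in the formalin test, with a stated time of 0.5 h (on this read-out lower numbers stand for an effect already at smaller amounts and higher numbers for an effect only at larger amounts of compound), compound 1 `COc1cc(OC)c(OC)cc1/C=C/COC(=O)/C=C/c1ccc(Br)cc1` gives 243 umol/kg, compound 2 `COc1cc(OC)c(OC)cc1/C=C/COC(=O)/C=C/c1ccccc1C(F)(F)F` gives 291 umol/kg and compound 3 `COc1cc(OC)c(OC)cc1/C=C/COC(=O)/C=C/c1ccccc1Cl` gives 260 umol/kg. Compound 3 therefore sits in a tight cluster, and its number cannot be told apart from the other two.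

Compound 4 `COc1cccc(/C=C/C(=O)OC/C=C/c2cc(OC)c(OC)cc2OC)c1` keeps the shared core and changes a single group. On a double-bonded chain carbon bound to a double-bonded chain carbon, 3-methoxyphenyl stands in place of 2-chlorophenyl: 3-methoxyphenyl in place of 2-chlorophenyl on a double-bonded chain carbon bound to a double-bonded chain carbon.

Three measured exchanges of the group at this same place bear on the question: a 1.2-fold higher number from compound 1 to compound 2 (0.08 log units; within the scatter), a 1.1-fold higher number from compound 1 to compound 3 (0.03 log units; within the scatter) and a 1.1-fold lower number from compound 2 to compound 3 (0.05 log units; within the scatter). All three are small, so no step beyond the scatter is expected in this assay. Going by the values given here, still, none of the measured compounds carries 3-methoxyphenyl, so the evidence is indirect and the range must stay generous.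

The expected step is a 1.0-fold higher number from compound 3 to compound 4 (0.02 log units; within the scatter). Compound 4 is estimated at 270 umol/kg, with an expected range of 160 umol/kg to 430 umol/kg.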

Compound 4, dose for half-maximal effect: > 260 umol/kg
Compound 4: no number, only a limit; the forecaster's own chance of this, stated with the estimate: 3%; the middle value is on the limit's open side.
By their numbers in this assay, from the lowest: compounds 1, 3 and 2 (each within the scatter of the next).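

At this place, on a double-bonded chain carbon bound to a double-bonded chain carbon, 3-methoxyphenyl is the only group shown that gives a limit rather than a number in this assay: the limit of > 260 umol/kg in this assay, at which 1 of the 4 values shown sits. Putting 3-methoxyphenyl in place of 2-chlorophenyl gives a number no lower from compound 3 to compound 4 (the limit leaves the size open), and putting it in place of 4-bromophenyl gives an at least 1.0-fold higher number from compound 1 to compound 4 (0.02 log units; that floor lies within the scatter). So this exchange brings no lower number than compound 3, yet how far compound 4 really lies from the others stays unknown, and its step with compound 2 cannot be read.

The compounds shown all carry a substituted phenyl group at this place, so they leave open what an amine or a carboxylic acid on that phenyl would do. On these data alone, a measured number for compound 4 also remains open.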